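A Fluorophenyl Replaces Tert-Butyl on the Amine Nitrogen

The source may hold more compounds than are shown below. What is called first, only, known or untested is meant among the compounds shown, and "the series" means these compounds.

Three measured compounds share one core and differ only in the group carried on a saturated chain carbon bound to a carbonyl carbon. Compound 1 `CC(C)(C)NCC(=O)Nc1nc2ccc(Cl)cc2s1` carries (tert-butyl)amino there, and in a functional assay on the whole organism with Mus musculus as the target, in the maximal electroshock model, with a stated time of 0.5 h (a lower number here means that less compound is needed, a higher number that more compound is needed for the effect), compound 1 gives 30 mg/kg. Compound 2 `O=C(Cn1ccnc1)Nc1nc2ccc(Cl)cc2s1` carries 1H-imidazol-1-yl in that place, and compound 2 gives 30 mg/kg. Compound 3 `O=C(CN1CCCCC1)Nc1nc2ccc(Cl)cc2s1` carries piperidin-1-yl, and compound 3 gives 30 mg/kg. Compound 1 thus stands level with both companions, and the three steps that connect them are flat: no change at the digits printed from compound 1 to compound 2 (within the scatter), no change at the digits printed from compound 1 to compound 3 (within the scatter) and no change at the digits printed from compound 2 to compound 3 (within the scatter).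

The unmeasured compound 4 `O=C(CNc1ccc(F)cc1)Nc1nc2ccc(Cl)cc2s1` keeps the same core and the same chain, with one change: 4-fluorophenyl in place of tert-butyl on an amine nitrogen. This change again touches only the group hanging off that chain, the same place where the three measured steps made no difference. All three steps bear on it, and each of them was within the scatter, so no step beyond the scatter is expected in either direction.

Compound 4 is therefore estimated at 30 mg/kg, with a range from 15 mg/kg to 100 mg/kg. The expected step of no change at the digits printed from compound 1 to compound 4 (within the scatter) is estimated to stay within the scatter.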

Compound 4, minimum effective dose: 100 mg/kg
The estimate for compound 4 lay 3.3-fold (0.52 log units) below the measured number; the measured number falls inside the stated range.
By their numbers in this assay, from the lowest: compounds 1, 2 and 3 (each within the scatter of the next); then compound 4.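

In this assay, the group on this chain is no longer without effect: 4-fluorophenyl in place of tert-butyl on the amine nitrogen gives a 3.3-fold higher number from compound 1 to compound 4 (0.52 log units; beyond the scatter), a modest step and the first at this position to lie beyond the scatter. Among the compounds shown here, the three earlier groups, (tert-butyl)amino, 1H-imidazol-1-yl and piperidin-1-yl, showed only that those particular swaps made no visible difference, whereas compound 4 shows that the number can move here, towards more compound being needed for the effect. No measurement shown gives a reason for this step, so it stands as an observation about this one change, with no explanation attached.

The compounds shown leave open whether the step belongs to the aromatic ring itself or to the fluorine on it, a question that a plain phenyl on the same amine nitrogen would address. They also leave open whether a group on this nitrogen can move the number the other way, towards less compound being needed, as a cyclohexyl or a benzyl in the same place might show.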